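Lengthening an alkyl chain on two related cores

This account rests on a few compounds, and the source may have more. Where it says the series, first, only, none or still open, it means among the compounds named here.

Of the compounds shown here, three built around an arylaminomethyl-imidazoline motif have been measured in an in vitro functional assay on cells (Fibroblast) for agonist activity at Alpha-1D adrenergic receptor (Homo sapiens); a lower number here means that less compound is needed, a higher number that more compound is needed for the effect. Compound 1 `CCn1ncnc1-c1ccccc1NCC1=NCCN1` gives 126 nM in this assay. Compound 2 `CCCn1ncnc1-c1ccccc1NCC1=NCCN1` differs from compound 1 by one change, (methyl in place of hydrogen on a saturated chain carbon, two bonds along the chain from an aromatic nitrogen), and in this assay compound 2 gives 251 nM. The step of a 2.0-fold higher number from compound 1 to compound 2 (0.30 log units; within the scatter) is therefore small. Compound 3 `Cn1ccc(-c2ccccc2NCC2=NCCN2)n1` carries a different core; how the two cores differ is not broken down here. In this assay compound 3 gives 15.9 nM, the lowest of the three numbers.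

Compound 4 `CCn1ccc(-c2ccccc2NCC2=NCCN2)n1` has not yet been measured. It differs from compound 3 by methyl in place of hydrogen on a saturated chain carbon bound to an aromatic nitrogen. This is the same kind of change as that from compound 1 to compound 2, though not the same: in compound 2 the entering methyl sits on a saturated chain carbon, two bonds along the chain from an aromatic nitrogen, whereas in compound 4 it sits on a saturated chain carbon bound to an aromatic nitrogen.

Among the measured compounds shown here, with the measured pair as the only guide, the expected step is a 1.6-fold higher number from compound 3 to compound 4 (0.20 log units; within the scatter), set beside the earlier one because a 2.0-fold higher number from compound 1 to compound 2 (0.30 log units; within the scatter) stayed within the scatter. The estimate rests on compound 3 and its value 15.9 nM. Compound 4 is therefore expected to give about 25 nM in this assay, most likely between 10 nM and 63 nM.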

Compound 4, half-maximal effective concentration: < 100000 nM
Compound 4: a limit, no number; the forecaster's own chance of this, stated with the estimate: 2%; the middle value is on the limit's open side.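

In this assay compound 4 gives no number, only a limit of the assay, < 100000 nM. The step from compound 3 to compound 4 therefore cannot be read, and the only thing to report is the limit itself: the limit of < 100000 nM in this assay, at which 1 of the 4 values shown sits.

The compounds shown leave open how far methyl in place of hydrogen on a saturated chain carbon bound to an aromatic nitrogen shifts the number in this assay on the core of compound 3.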